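From Pyrimidin-2-yl to 1,3-Thiazol-2-yl: A Clearance Estimate

The source may report more compounds than this note shows. Statements on the series, on what has been measured and on what is new or still open speak of the compounds shown alone.

- Compound 1 `O=C(COCc1ccccc1)N1CCN(c2ccc(Cl)cc2Cl)CC1`: 450 mL.min-1.g-1
- Compound 2 `O=C(COCc1cnccn1)N1CCN(c2ccc(Cl)cc2Cl)CC1`: 4 mL.min-1.g-1
- Compound 3 `O=C(COCc1ncccn1)N1CCN(c2ccc(Cl)cc2Cl)CC1`: 16 mL.min-1.g-1

In an in vitro ADME assay on microsomes from liver (Homo sapiens) for metabolic stability (on this read-out lower numbers stand for slow clearance and higher numbers for fast clearance), compound 3 holds the second highest of the three numbers, at 16 mL.min-1.g-1. The unmeasured compound 4 `O=C(COCc1nccs1)N1CCN(c2ccc(Cl)cc2Cl)CC1` differs from it in one group: 1,3-thiazol-2-yl in place of pyrimidin-2-yl on a saturated chain carbon bound to an oxygen on a saturated carbon. The swap sits on a saturated chain carbon bound to an oxygen on a saturated carbon, where all three measured steps also took place. Putting pyrazin-2-yl in place of phenyl gave a 110-fold lower number from compound 1 to compound 2 (2.05 log units; beyond the scatter), and putting pyrimidin-2-yl in place of phenyl gave a 28-fold lower number from compound 1 to compound 3 (1.45 log units; beyond the scatter). Both steps are large. The closest guide is the modest 4.0-fold higher number from compound 2 to compound 3 (0.60 log units; beyond the scatter), a swap of one hetero-atom ring for another. Among the compounds with values here, no measured compound carries 1,3-thiazol-2-yl, so this comparison is only a rough guide. A modest rise is expected, a 2.5-fold higher number from compound 3 to compound 4 (0.40 log units; beyond the scatter). Compound 4 is estimated at 40 mL.min-1.g-1, with an expected range of 12 mL.min-1.g-1 to 130 mL.min-1.g-1.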

Compound 4, intrinsic clearance in microsomes: 80 mL.min-1.g-1
Compound 4: middle estimate off by 2.0-fold (0.30 log units), on the low side; low and high end bracket the measured number.
By their numbers in this assay, from the lowest: compound 2; then compound 3; then compound 4; then compound 1.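

Swapping the six-membered ring for a five-membered one, with the same count of hetero atoms and hydrogen-bond acceptors, still moves the read-out in this assay (a 5.0-fold higher number from compound 3 to compound 4 (0.70 log units; beyond the scatter)), so among these compounds that count alone does not fix the clearance at this position. Swaps among hetero-atom rings had so far been only modest, but one can also be large (a 20-fold higher number from compound 2 to compound 4 (1.30 log units; beyond the scatter)). Against the phenyl compound, the 1,3-thiazol-2-yl ring brings only a modest drop (a 5.6-fold lower number from compound 1 to compound 4 (0.75 log units; beyond the scatter)), whereas the pyrazin-2-yl and pyrimidin-2-yl rings each brought a large one.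

Still open is where a pyridin-2-yl ring, with a single ring nitrogen, or an oxazol-2-yl ring, with oxygen in place of the sulfur, would fall among these compounds. Nothing available explains why these rings differ.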